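Allyloxy oxime in the amino-pyrimidine ether series

The compounds below may be only part of what the source reports. "The series", "measured", "known", "first", "only" and "open" are said of these compounds alone.

Compound 1 `CCO/N=C/c1c(N)ncnc1Oc1ccc2[nH]c(C)cc2c1F` is the reference point of this set. In a functional assay on A-375 cells (Homo sapiens) for antiproliferative activity (on this read-out lower numbers stand for stronger inhibition and higher numbers for weaker inhibition), compound 1 gives 27 nM, the lowest of the three numbers in hand. Compound 3 `CCCCO/N=C/c1c(N)ncnc1Oc1ccc2[nH]c(C)cc2c1F` gives 446 nM. Within the data shown here, compound 2 `CO/N=C/c1c(N)ncnc1Oc1ccc2[nH]ccc2c1` differs from compound 1 in several places at once, and in this assay compound 2 gives 783 nM; of that pair only the two values themselves can be compared, since no single step links them.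

Among the measured compounds shown here, the one measured step that bears on the present question is a 17-fold higher number from compound 1 to compound 3 (1.22 log units; beyond the scatter), with ethyl in place of hydrogen on a saturated chain carbon, two bonds along the chain from an oxygen on an unsaturated carbon. Lengthening the chain on the oxime oxygen is therefore costly in this assay.

Compound 4 `C=CCO/N=C/c1c(N)ncnc1Oc1ccc2[nH]c(C)cc2c1F` differs from compound 1 by vinyl in place of methyl on a saturated chain carbon bound to an oxygen on an unsaturated carbon; cut one bond further out, the change reads ethyl to allyl, or ethoxy to allyloxy. The chain grows here as well, but by fewer heavy atoms than in compound 3, so a smaller rise than in a 17-fold higher number from compound 1 to compound 3 (1.22 log units; beyond the scatter) is expected, in the same direction.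

For compound 4 in this assay a value of 90 nM is estimated, in the range 35 nM to 250 nM, which amounts to an expected step of a 3.3-fold higher number from compound 1 to compound 4 (0.52 log units; beyond the scatter).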

Compound 4, half-maximal inhibitory concentration: 21 nM
Compound 4: the middle estimate sits 4.3-fold (0.63 log units) above what was measured; the measured number lies below the stated range.
By their numbers in this assay, from the lowest: compounds 4 and 1 (each within the scatter of the next); then compounds 3 and 2 (each within the scatter of the next).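

On the oxime oxygen, in this assay, allyl in place of ethyl gives a 1.3-fold lower number from compound 1 to compound 4 (0.11 log units; within the scatter), so this position takes the vinyl end group, with its one double bond outside aromatic rings and one more heavy atom than the methyl it replaces, without a readable change. Set against the chain of compound 3, the same allyl group gives a 21-fold lower number from compound 3 to compound 4 (1.33 log units; beyond the scatter), which shows that the loss seen with compound 3 does not follow from every extension of the ethyl chain and that the position tolerates some growth before the read-out rises sharply. No measurement in hand accounts for the gap between the allyl and the longer saturated chain.

The step from compound 3 to compound 4 changes both chain length and saturation at once, so the compounds shown do not separate the contribution of the double bond from that of the length. A saturated propyl chain or a propargyl chain on the oxime oxygen, on the core of compound 1, would separate the two and mark more closely where the rise begins.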